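The source may hold more compounds than are shown below. What is called first, only, known or untested is meant among the compounds shown, and "the series" means these compounds.

Measured so far in a functional assay on HL-60 cells (Homo sapiens) for inhibition, read by CCK-8 assay, with a stated time of 48 h; on this read-out higher numbers stand for weaker inhibition and lower numbers for stronger inhibition:
compound 1 `O=C(NCCNS(=O)(=O)c1ccc(-c2ccccc2O[C@H]2CC[C@H](O)CC2)s1)Nc1cc(Cl)cc(Cl)c1` — reported only as a limit, > 20000 nM.
compound 2 `O=C(NCCNS(=O)(=O)c1ccc(-c2ccccc2OCc2ccccc2)s1)Nc1cc(C(F)(F)F)cc(C(F)(F)F)c1` — 11400 nM.
compound 3 `O=S(=O)(NCCNC(=S)Nc1cc(C(F)(F)F)cc(C(F)(F)F)c1)c1cc(-c2ccccc2Oc2ccc(O)c(O)c2)cs1` — 600 nM.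

The entry for compound 1 is a limit of this assay (the limit of > 20000 nM in this assay, at which 1 of the 3 values shown sits), not a number. Of the two numbers shown, compound 2 holds the higher one; compound 3 sits below it by more than the scatter, though the two structures differ in several places and no single step joins them. Compound 4 `O=C(NCCNS(=O)(=O)c1ccc(-c2ccccc2OCc2cccc(O)c2)s1)Nc1cc(C(F)(F)F)cc(C(F)(F)F)c1` is the untested neighbour of compound 2. The change: hydroxy in place of hydrogen on an aromatic carbon. Among the compounds with values here, no measured pair shows this change, so only a modest step is expected, a 1.6-fold lower number from compound 2 to compound 4 (0.21 log units; within the scatter), toward stronger inhibition and barely past the scatter. Compound 4 is thus expected near 7000 nM, between 2500 nM and 20000 nM.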

Compound 4, half-maximal inhibitory concentration: 4000 nM
For compound 4 the middle estimate is 1.8-fold (0.24 log units) above the measured one, within the range that was stated.
By their numbers in this assay, from the lowest: compound 3; then compound 4; then compound 2. At a limit, above all of these: compound 1.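

In this assay, within the data shown here, the change from phenyl to 3-hydroxyphenyl within the benzyloxy group gives a 2.9-fold lower number from compound 2 to compound 4 (0.45 log units; beyond the scatter), the first step that isolates a change in one place. This ring therefore accepts a hydroxy at this position, with the number moving toward stronger inhibition.

Still open, from the compounds shown here alone, is whether a methoxy, an amine or a carboxylic acid at this same position would move the number the same way, and how a hydroxy would fare elsewhere on this ring. Nothing shown here gives a cause for the step.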